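Swapping a Propyl for Cyclobutyl on the Ring Amine

The source may hold more compounds than are shown below. What is called first, only, known or untested is meant among the compounds shown, and "the series" means these compounds.

Measured compounds:
compound 1 `Cc1ccc(S(=O)(=O)N2C=CNC(=O)[C@H]2CC(=O)N[C@@H]2CCc3ccccc32)cc1` gives 94.7 nM
compound 2 `Cc1ccc(S(=O)(=O)N2C=CNC(=O)[C@H]2CC(=O)NC2CCCCC2C)cc1` gives 25.9 nM
compound 3 `CCCN1CC[C@H](NC(=O)C[C@@H]2C(=O)NC=CN2S(=O)(=O)c2ccc(C)cc2)C(C)(C)C1` gives 0.51 nM

All three share a core and were tested in an in vitro functional assay on cells for antagonist activity at B1 bradykinin receptor (Homo sapiens), read by luminescence and calcium flux, with a stated time of 2 h; on this read-out higher numbers stand for weaker inhibition and lower numbers for stronger inhibition. Compound 3 stands lowest of the three, clearly separated from compound 2 and compound 1, whose numbers are far higher. Between compound 1 and compound 2 the only single-point change so far is a 3.7-fold lower number from compound 1 to compound 2 (0.56 log units; beyond the scatter), where a 2-methylcyclohexyl replaces the 2,3-dihydro-1H-inden-1-yl group on the amide-type nitrogen.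

Compound 4 `Cc1ccc(S(=O)(=O)N2C=CNC(=O)[C@H]2CC(=O)N[C@H]2CCN(C3CCC3)CC2(C)C)cc1` has not yet been measured. It differs from compound 3 in one place: cyclobutyl in place of propyl on an amine nitrogen in a ring. Within the data shown here, this change sits on the amine nitrogen in the six-membered ring, not on the amide-type nitrogen where the one measured step occurred, so that step does not bear on it directly. Nothing in the measured compounds tells how this ring amine tolerates a change from a short chain to a small ring.

In the absence of a comparable step, the expectation is that compound 4 stays close to compound 3, with a change a 1.2-fold higher number from compound 3 to compound 4 (0.07 log units; within the scatter) not beyond the scatter. Compound 4 is therefore estimated at 0.6 nM, within a range of 0.2 nM to 2 nM.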

Compound 4, half-maximal inhibitory concentration: 0.74 nM
The estimate for compound 4 lay 1.2-fold (0.09 log units) below the measured number, and the stated range covers the measured number.
By their numbers in this assay, from the lowest: compounds 3 and 4 (each within the scatter of the next); then compound 2; then compound 1.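

In this assay the exchange of propyl for cyclobutyl on the amine nitrogen of the six-membered ring gives a 1.5-fold higher number from compound 3 to compound 4 (0.16 log units; within the scatter) and so does not separate the two compounds. This is the first view of this position in the compounds shown, and it indicates that the open chain of 3 heavy atoms and the four-membered carbon ring of 4 heavy atoms are both compatible with numbers in the same low range on this read-out. No supporting data are available to explain why these two groups read alike.

On these data alone, with only propyl and cyclobutyl on this nitrogen, the limits of this tolerance remain open: a longer chain such as hexyl, a larger ring such as cyclohexyl, or a ring containing oxygen such as tetrahydropyranyl might read quite differently. Also unknown is whether this nitrogen needs a carbon group of this kind at all, since neither a plain hydrogen nor an acetyl group there can be compared with the two groups shown.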